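From Propoxy to Allyloxy on a Shared Core

This account rests on a few compounds, and the source may have more. Where it says the series, first, only, none or still open, it means among the compounds named here.

In a functional assay on the whole organism (strain Sprague-Dawley) for inhibition, with Rattus norvegicus as the target, with a stated time of 10 min (a lower number here means that less compound is needed, a higher number that more compound is needed for the effect), compound 1 `O=C(O)c1cnc(-c2ccccc2O)[nH]c1=O` gives > 5 mg/kg, which is a limit of the assay and not a number. Compound 2 `CCOc1ccccc1-c1ncc(C(=O)O)c(=O)[nH]1` gives 0.5 mg/kg. Compound 3 `CCCOc1ccccc1-c1ncc(C(=O)O)c(=O)[nH]1` gives 0.9 mg/kg, level with compound 2 once the usual scatter is allowed for.

Compound 4 `C=CCOc1ccccc1-c1ncc(C(=O)O)c(=O)[nH]1` has vinyl in place of ethyl on a saturated chain carbon bound to an oxygen on an aromatic ring, so propoxy becomes allyloxy (vinyl in place of ethyl on a saturated chain carbon bound to an oxygen on an aromatic ring).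

Two large steps came from putting a chain on that oxygen: an at least 10-fold lower number from compound 1 to compound 2 (1.00 log units; beyond the scatter) and an at least 5.5-fold lower number from compound 1 to compound 3 (0.74 log units; beyond the scatter). Among the compounds with values here, compound 4 keeps such a chain, so those steps say only that its number should stay well clear of the limit. The closest guide is the change within the chain itself, a 1.8-fold higher number from compound 2 to compound 3 (0.26 log units; within the scatter), and that step is small. The expected outcome is therefore no change beyond the scatter, namely a 1.3-fold lower number from compound 3 to compound 4 (0.11 log units; within the scatter). The estimate for compound 4 is 0.7 mg/kg, with an expected range of 0.35 mg/kg to 1.5 mg/kg.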

Compound 4, dose for 50% inhibition: 0.5 mg/kg
The estimate for compound 4 lay 1.4-fold (0.15 log units) above the measured number; the range from low to high includes it.
By their numbers in this assay, from the lowest: compounds 2, 4 and 3 (each within the scatter of the next). At a limit, above all of these: compound 1.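

Unsaturation at this position changes little in this assay: vinyl in place of ethyl on a saturated chain carbon bound to an oxygen on an aromatic ring gives a 1.8-fold lower number from compound 3 to compound 4 (0.26 log units; within the scatter), and the comparison with the ethoxy chain of compound 2 gives no change at the digits printed from compound 2 to compound 4 (within the scatter). An allyl group on that oxygen also matches the two saturated chains in its large step away from the free hydroxyl, with an at least 10-fold lower number from compound 1 to compound 4 (1.00 log units; beyond the scatter), so among compounds 2, 3 and 4 none goes against this pattern. The size of that step remains a minimum, as compound 1 gives a limit and not a number: the limit of > 5 mg/kg in this assay, at which 1 of the 4 values shown sits.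

The compounds shown leave open how a methyl group, the shortest chain, would behave on this oxygen. They also leave open whether a longer chain such as hexyl, or a chain ending in an amine, would keep the number this low.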